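This account rests on a few compounds, and the source may have more. Where it says the series, first, only, none or still open, it means among the compounds named here.

Measured so far in a functional assay on LNCaP cells (Homo sapiens) for antiproliferative activity; a higher number here means a weaker inhibitor, a lower number a stronger inhibitor:
compound 1 `Cn1ncc(Cl)c1-c1cc(C(=O)N[C@@H]2CN[C@H](CCNS(C)(=O)=O)C[C@H]2c2ccc(F)c(F)c2)oc1Cl`: 50 nM
compound 2 `Cn1ncc(Cl)c1-c1cc(C(=O)N[C@@H]2CN[C@H](CC(O)CO)C[C@H]2c2ccc(F)c(F)c2)oc1Cl`: 100 nM

Compound 2 does not separate from compound 1, as their values lie within the scatter of each other. Compound 3 `Cn1ncc(Cl)c1-c1cc(C(=O)N[C@@H]2CN[C@H](CCO)C[C@H]2c2ccc(F)c(F)c2)oc1Cl` differs from compound 2 by hydrogen in place of hydroxymethyl on a saturated chain carbon bound to an oxygen on a saturated carbon and a saturated chain carbon, which reads as 2,3-dihydroxypropyl to 2-hydroxyethyl. Among the compounds with values here, the only measured step on this substituent, a 2.0-fold higher number from compound 1 to compound 2 (0.30 log units; within the scatter), stayed within the scatter, so no shift beyond the scatter is expected in this assay, and no direction can be argued. The expected change is small: a 1.4-fold lower number from compound 2 to compound 3 (0.15 log units; within the scatter). For compound 3 the estimated value is 70 nM, with an expected range of 25 nM to 200 nM.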

Compound 3, half-maximal inhibitory concentration: 60 nM
Compound 3: middle estimate off by 1.2-fold (0.07 log units), on the high side; measured number inside the range.
By their numbers in this assay, from the lowest: compounds 1, 3 and 2 (each within the scatter of the next).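

In this assay, hydrogen in place of hydroxymethyl gives a 1.7-fold lower number from compound 2 to compound 3 (0.22 log units; within the scatter) and hydroxy in place of methanesulfonamido gives a 1.2-fold higher number from compound 1 to compound 3 (0.08 log units; within the scatter) on the same side chain. The 2-hydroxyethyl, 2,3-dihydroxypropyl and methanesulfonamido-bearing chains of these three compounds therefore cannot be told apart here, and the second hydroxy of compound 2 shows no measurable contribution. No evidence on hand bears on this result. Still open, as far as these compounds go, is whether an amine, a carboxylic acid or a plain ethyl group in place of 2-hydroxyethyl would move the number in this assay beyond the scatter.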